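The compounds below may be only part of what the source reports. "The series", "measured", "known", "first", "only" and "open" are said of these compounds alone.

Measured so far in a functional assay on cells with Free fatty acid receptor 1 (Homo sapiens) as the target, read by FLIPR and calcium flux, with stated times of 20 s and 100 s; a lower number here means that less compound is needed, a higher number that more compound is needed for the effect:
compound 1, `O=C1NC(=O)C(Cc2ccc(OCCOC(c3ccccc3)c3ccccc3)cc2)S1`, 21300 nM
compound 2, `COc1ccc(C(OCCOc2ccc(CC3SC(=O)NC3=O)cc2)c2ccccc2)cc1`, 17800 nM

Compound 2 has the lowest of the two numbers in this assay, but its nearest neighbour, compound 1, lies within the scatter of it, so the two are not separated. Within the data shown here, the only step between measured compounds, a 1.2-fold lower number from compound 1 to compound 2 (0.08 log units; within the scatter), puts a methoxy group on an aromatic carbon where compound 1 carries hydrogen, and it stays within the scatter. Compound 3, `O=C1NC(=O)C(Cc2ccc(OCCOC(c3ccccc3)c3ccc(C(F)(F)F)cc3)cc2)S1`, is not yet measured. It differs from compound 2 in one place: trifluoromethyl in place of methoxy on an aromatic carbon. Among the measured compounds shown here, the one measured step bears on this only loosely: it shows that methoxy on that aromatic carbon changed little against hydrogen, while nothing measured shows what trifluoromethyl does there. With that, the step expected is a 1.2-fold lower number from compound 2 to compound 3 (0.07 log units; within the scatter), in no direction that can be called beyond the scatter. The estimate for compound 3 in this assay is 15000 nM, with a range from 6000 nM to 40000 nM.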

Compound 3, half-maximal effective concentration: 11300 nM
Estimate against measurement, compound 3: 1.3-fold (0.12 log units) above; measured number inside the range.
By their numbers in this assay, from the lowest: compounds 3, 2 and 1 (each within the scatter of the next).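

In this assay the position now carries a second substituent, and trifluoromethyl in place of methoxy gives a 1.6-fold lower number from compound 2 to compound 3 (0.20 log units; within the scatter). This swap adds heavy atoms and removes the one hydrogen-bond acceptor of methoxy, yet it does not separate the two compounds, and trifluoromethyl in place of hydrogen, with a 1.9-fold lower number from compound 1 to compound 3 (0.28 log units; within the scatter), does not separate those two either, so hydrogen, methoxy and trifluoromethyl on this aromatic carbon remain indistinguishable in this assay. No supporting data are available that could explain this result.

On these data alone, whether an amine or a carboxylic acid on this same aromatic carbon would move the number beyond the scatter remains open. Also open, as far as these compounds go, is what a longer chain in place of the one joining the diphenylmethyl-type end to the shared core would do.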